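From 3-methoxyphenyl to 4-cyanophenyl in an inactive series

The source may hold more compounds than are shown below. What is called first, only, known or untested is meant among the compounds shown, and "the series" means these compounds.

Two compounds have results so far, and neither gives a measured potency. In a functional assay on CWR22R cells (Homo sapiens) for antiproliferative activity, with a stated time of 96 h (a lower number here means a stronger inhibitor, a higher number a weaker inhibitor), compound 1 `Cc1cc(=O)oc2cc(OCC(=O)c3ccc4c(c3)OCCCO4)ccc12` gives > 100000 nM as its result, which is a limit of the assay and not a number. Compound 2 `COc1cccc(C(=O)COc2ccc3c(C(F)(F)F)cc(=O)oc3c2)c1` has no single number and is recorded as "not active" (no number reported) in this assay so there is no figure from which to measure a step.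

Compound 3 `N#Cc1ccc(C(=O)COc2ccc3c(C(F)(F)F)cc(=O)oc3c2)cc1` keeps the rest of compound 2 and exchanges one group, with 4-cyanophenyl in place of 3-methoxyphenyl on a carbonyl carbon. Among the compounds with values here, the series holds no measured step that shows what such an exchange does. With compound 2 recorded as "not active" (no number reported) and no measurable potency yet in the series, only a modest step toward stronger inhibition is expected, if any. For compound 3, another result given only as a limit is quite possible. In this assay compound 3 is estimated at 40000 nM with an expected range from 5000 nM to 100000 nM as a working figure.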

Compound 3, half-maximal inhibitory concentration: "not active" (no number reported)
Compound 3 has no reported number here; no gap can be computed for the estimate.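

Compound 2 and compound 3 both stand without a number in this assay, so no step can be read between them. The compounds shown leave open whether 4-cyanophenyl in place of 3-methoxyphenyl on a carbonyl carbon changes the result at all, and whether this series gives a value beyond the one bound seen so far: the limit of > 100000 nM in this assay, at which 1 of the 3 values shown sits.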